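Swapping Fluoro for Methyl on a Weakly Cytotoxic Core

The compounds below may be only part of what the source reports. "The series", "measured", "known", "first", "only" and "open" are said of these compounds alone.

Measured so far:
Compound 1 `CN(C)CCN1CCN(CC(=O)Nc2ccc(-c3nc4cc(F)ccc4o3)cc2)CC1`: 72000 nM
Compound 2 `Cc1cc(-c2nc3cc(F)ccc3o2)ccc1NC(=O)CN1CCN(CCN(C)C)CC1`: 62100 nM

In an ADME assay on NIH3T3 cells (Mus musculus) for cytotoxicity, read by MTT assay, with a stated time of 24 h (a lower number here means a stronger inhibitor, a higher number a weaker inhibitor), compound 1 gives 72000 nM, the highest of the two numbers; compound 2 sits nearest, and the step of a 1.2-fold lower number from compound 1 to compound 2 (0.06 log units; within the scatter) lies within the scatter. Compound 3 `Cc1ccc2oc(-c3ccc(NC(=O)CN4CCN(CCN(C)C)CC4)cc3)nc2c1` is not yet measured. It differs from compound 1 by methyl in place of fluoro on an aromatic carbon. For the measured compounds named here, no measured step removes the fluoro; the single measured step, a 1.2-fold lower number from compound 1 to compound 2 (0.06 log units; within the scatter), concerns another change and shows no movement beyond the scatter. The expected step is therefore a 1.0-fold lower number from compound 1 to compound 3 (0.01 log units; within the scatter), with no change beyond the scatter. Compound 3 is estimated at 70000 nM, between 30000 nM and 160000 nM.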

Compound 3, half-maximal inhibitory concentration: 28900 nM
For compound 3 the middle estimate is 2.4-fold (0.38 log units) above the measured one, outside the stated range (below it).
By their numbers in this assay, from the lowest: compound 3; then compounds 2 and 1 (each within the scatter of the next).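

In this assay, changing 5-fluoro-1,3-benzoxazol-2-yl to 5-methyl-1,3-benzoxazol-2-yl gives a 2.5-fold lower number from compound 1 to compound 3 (0.40 log units; beyond the scatter), a modest step but the first beyond the scatter. For the compounds shown here, this position on the shared core can therefore shift the number, something the only earlier step, a 1.2-fold lower number from compound 1 to compound 2 (0.06 log units; within the scatter), a methyl change elsewhere, did not show. No measurement here accounts for the shift.

The compounds shown leave open whether the lower number follows the loss of fluoro or the arrival of methyl. Hydrogen, chloro or methoxy at this position would help separate the two.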